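The compounds below may be only part of what the source reports. "The series", "measured", "known", "first", "only" and "open" are said of these compounds alone.

In a functional assay on HeLa cells (Homo sapiens) for antiproliferative activity, read by sulforhodamine B assay, with a stated time of 48 h (a higher number here means a weaker inhibitor, a lower number a stronger inhibitor), compound 3 `COc1ccc2nc(-c3ccc(N/C=C\C(=O)c4ccc(OC)c(O)c4)cc3)sc2c1` gives 6900 nM, close to compound 1 `COc1ccc2nc(-c3ccc(N/C=C\C(=O)c4ccc(OC)c(O)c4)c(C)c3)sc2c1` at 12000 nM, whereas compound 2 `COc1ccc(C(=O)/C=C\Nc2ccc(-c3nc4cc(OC)c(OC)c(OC)c4s3)cc2C)cc1F` gives a lower 1200 nM. Compound 4 `COc1ccc2nc(-c3ccc(N/C=C\C(=O)c4ccc(OC)c([N+](=O)[O-])c4)cc3)sc2c1` carries nitro in place of hydroxy on an aromatic carbon, ortho to a methoxy group (nitro in place of hydroxy on an aromatic carbon). Going by the values given here, the only measured step, hydrogen in place of methyl on an aromatic carbon, is a 1.7-fold lower number from compound 1 to compound 3 (0.24 log units; within the scatter). Among the compounds with values here, it involves a different change, so no measured step tests this replacement. The data give no direction, and no shift beyond the scatter is expected in this assay, although the uncertainty is wide. The expected step is a 1.2-fold lower number from compound 3 to compound 4 (0.06 log units; within the scatter). For compound 4 the estimated value is 6000 nM, with an expected range from 1800 nM to 20000 nM.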

Compound 4, half-maximal inhibitory concentration: 17600 nM
For compound 4 the middle estimate is 2.9-fold (0.47 log units) below the measured one; measured number inside the range.
By their numbers in this assay, from the lowest: compound 2; then compounds 3, 1 and 4 (each within the scatter of the next, the first and the last beyond it).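

In this assay, nitro in place of hydroxy, on the carbon ortho to a methoxy group, gives a 2.6-fold higher number from compound 3 to compound 4 (0.41 log units; beyond the scatter), a modest step but one beyond the scatter. Going by these compounds alone, this is the first measured change at this position, and it shows that the number responds to the group placed there, whereas the only earlier step, at a different place, stayed within the scatter. No available evidence accounts for this step. Going by these compounds, whether an amine or a carboxylic acid on this carbon would bring the number nearer that of compound 3 or compound 4 remains open.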